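The source may report more compounds than this note shows. Statements on the series, on what has been measured and on what is new or still open speak of the compounds shown alone.

Compound 3 `Cc1cc(=O)n(-c2ccc(Br)cc2F)nc1C(=O)Nc1ccc(Oc2ncnc3[nH]ccc23)c(F)c1` gives the lowest of the three numbers in a functional assay on A549 cells (Homo sapiens) for cytotoxicity, read by MTT assay, with a stated time of 72 h (on this read-out higher numbers stand for weaker inhibition and lower numbers for stronger inhibition), at 6120 nM. Compound 1 `Cc1cc(=O)n(-c2cccc(F)c2)nc1C(=O)Nc1ccc(Oc2ncnc3[nH]ccc23)c(F)c1` gives 31500 nM and compound 2 `Cc1cc(=O)n(-c2ccccc2OC(F)(F)F)nc1C(=O)Nc1ccc(Oc2ncnc3[nH]ccc23)c(F)c1` gives 16200 nM. Compound 4 `Cc1cc(=O)n(-c2cccc(C(F)(F)F)c2)nc1C(=O)Nc1ccc(Oc2ncnc3[nH]ccc23)c(F)c1` differs from compound 3 in one place: 3-(trifluoromethyl)phenyl in place of 4-bromo-2-fluorophenyl on an aromatic nitrogen. Going by the values given here, two measured steps bear on this position, since both change the same group: a 5.1-fold lower number from compound 1 to compound 3 (0.71 log units; beyond the scatter) and a 2.6-fold lower number from compound 2 to compound 3 (0.42 log units; beyond the scatter). Both moved toward compound 3. Replacing its 4-bromo-2-fluorophenyl with a group that resembles the 3-fluorophenyl of compound 1 is expected to give back part of that gain, so a modest rise in the number is expected, with the estimated step being a 2.5-fold higher number from compound 3 to compound 4 (0.39 log units; beyond the scatter). Compound 4 is therefore expected to give about 15000 nM, within a range from 5000 nM to 45000 nM.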

Compound 4, half-maximal inhibitory concentration: 35100 nM
For compound 4 the middle estimate is 2.3-fold (0.37 log units) below the measured one; low and high end bracket the measured number.
By their numbers in this assay, from the lowest: compound 3; then compounds 2, 1 and 4 (each within the scatter of the next, the first and the last beyond it).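

Bringing in 3-(trifluoromethyl)phenyl gives a 5.7-fold higher number from compound 3 to compound 4 (0.76 log units; beyond the scatter) and also a 2.2-fold higher number from compound 2 to compound 4 (0.34 log units; beyond the scatter), so this group does not keep the lower numbers of either compound. Trifluoromethyl in place of fluoro on the aromatic carbon gives only a 1.1-fold higher number from compound 1 to compound 4 (0.05 log units; within the scatter), so this larger group reads the same as the smaller one. No measurement shown explains these differences.

Going by these compounds, what stays open is whether the bromo or the fluoro in 4-bromo-2-fluorophenyl accounts for the lower number of compound 3, since the two never change separately here. On these data alone, how an amine or a carboxylic acid on this phenyl ring would read also remains open.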